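The compounds below may be only part of what the source reports. "The series", "measured", "known", "first", "only" and "open" are said of these compounds alone.

Three compounds have been measured in a functional assay on MGC-803 cells (Homo sapiens) for inhibition, read by sulforhodamine B assay; on this read-out lower numbers stand for stronger inhibition and higher numbers for weaker inhibition:

compound 1 `O=C1C=C(NCc2ccccc2)C(=O)c2c1nc1n2[C@H]2OC[C@@H](O)[C@H]2OC1` gives 2670 nM
compound 2 `O=C1C=C(Nc2ccccc2F)C(=O)c2c1nc1n2[C@H]2OC[C@@H](O)[C@H]2OC1` gives 2080 nM
compound 3 `Cc1ccc(NC2=CC(=O)c3c(nc4n3[C@H]3OC[C@@H](O)[C@H]3OC4)C2=O)cc1` gives 1550 nM

Compound 3 carries the lowest of the three numbers, but its separation from compound 2 and its separation from compound 1 both lie within the scatter, so the three measured compounds cannot be told apart on this read-out.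

Compound 4 `COc1cccc(NC2=CC(=O)c3c(nc4n3[C@H]3OC[C@@H](O)[C@H]3OC4)C2=O)c1` is the next compound, and it differs from compound 3 in one place: 3-methoxyphenyl in place of 4-methylphenyl on an amine nitrogen.

Among the measured compounds shown here, only one measured step sits on the same amine nitrogen, a 1.3-fold lower number from compound 1 to compound 2 (0.11 log units; within the scatter), and it swaps benzyl for 2-fluorophenyl rather than moving between two substituted phenyl groups. For the measured compounds named here, nothing among the measured compounds tests a methoxy group or a change from one substituted phenyl to another. With every change so far on this nitrogen staying within the scatter, the step to compound 4 is expected to stay within it too, a 1.1-fold higher number from compound 3 to compound 4 (0.04 log units; within the scatter), with no direction favoured.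

Compound 4 is therefore expected to give about 1700 nM in this assay, in a range from 700 nM to 4000 nM.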

Compound 4, half-maximal inhibitory concentration: 1790 nM
Beside the measured number, compound 4's estimate is 1.1-fold (0.02 log units) below it, and the stated range covers the measured number.
By their numbers in this assay, from the lowest: compounds 3, 4, 2 and 1 (each within the scatter of the next).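

In this assay, the step between two substituted phenyl groups on the amine nitrogen is a 1.2-fold higher number from compound 3 to compound 4 (0.06 log units; within the scatter). Among the compounds shown here, until now, the only step at this nitrogen had exchanged benzyl for 2-fluorophenyl; this one shows that replacing 4-methylphenyl with 3-methoxyphenyl, which adds an oxygen and a hydrogen-bond acceptor, also leaves the number within the scatter, and that the methoxy group and the changed substituent place together produce no separation on this read-out. Nothing available explains why these groups cannot be told apart, and no supporting evidence bears on this step.

Going by these compounds, all four groups on this nitrogen are benzyl or substituted phenyl groups, so it remains open whether a group of another kind, such as a chain ending in a tertiary amine, a carboxylic acid or a longer alkyl chain, would move the number beyond the scatter. On these data alone, it is also open whether any change at this nitrogen would separate compounds in this assay, or whether changes elsewhere on the shared core, such as to its hydroxyl group, would do so instead.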